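This account rests on a few compounds, and the source may have more. Where it says the series, first, only, none or still open, it means among the compounds named here.

Compound 1 `COc1ccc(-c2cc3ccccc3nc2/C=C/C(=O)c2ccc(F)cc2)cc1` gives 830 nM in a functional assay on MDA-MB-231 cells (Homo sapiens) for antiproliferative activity, read by XTT assay, with a stated time of 72 h (on this read-out higher numbers stand for weaker inhibition and lower numbers for stronger inhibition), compound 2 `COc1ccc(-c2cc3ccccc3nc2/C=C/C(=O)c2c(OC)cccc2OC)cc1` gives 5630 nM, and compound 3 `COc1ccc(-c2cc3ccccc3nc2/C=C/C(=O)c2ccc([N+](=O)[O-])cc2)cc1` gives 840 nM. Compound 3 stands second highest of the three, a hair from compound 1 and well apart from compound 2: a 6.7-fold lower number from compound 2 to compound 3 (0.83 log units; beyond the scatter). Compound 4 `COc1ccc(-c2cc3ccccc3nc2/C=C/C(=O)c2sccc2N)cc1` differs from compound 3 in one place: 3-aminothiophen-2-yl in place of 4-nitrophenyl on a carbonyl carbon. For the measured compounds named here, two measured steps bear on exchanges of the aryl group on the carbonyl carbon, a 6.8-fold higher number from compound 1 to compound 2 (0.83 log units; beyond the scatter) and a 6.7-fold lower number from compound 2 to compound 3 (0.83 log units; beyond the scatter), while a 1.0-fold higher number from compound 1 to compound 3 (0.01 log units; within the scatter) shows that a change on the aromatic ring alone need not move the number. Going by the values given here, no measured compound carries a five-membered ring here, so the direction is uncertain; a modest rise is expected, a 1.8-fold higher number from compound 3 to compound 4 (0.25 log units; within the scatter). Compound 4 is therefore estimated at 1500 nM, between 500 nM and 5000 nM.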

Compound 4, half-maximal inhibitory concentration: > 10000 nM
Compound 4: a limit, no number; the forecaster's own chance of this, stated with the estimate: 5%; middle value at least 6.6-fold (0.82 log units) away from the limit.
By their numbers in this assay, from the lowest: compounds 1 and 3 (each within the scatter of the next); then compound 2. At a limit, above all of these: compound 4.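

In this assay compound 4 gives a limit and no number: the limit of > 10000 nM in this assay, at which 1 of the 4 values shown sits. On this carbonyl carbon, 3-aminothiophen-2-yl produces the largest steps yet seen, an at least 11-fold higher number from compound 3 to compound 4 (1.07 log units; beyond the scatter) and an at least 12-fold higher number from compound 1 to compound 4 (1.08 log units; beyond the scatter), so this position can tolerate less than the near-identical values for the 4-fluorophenyl and 4-nitrophenyl groups suggested. The remaining step, an at least 1.7-fold higher number from compound 2 to compound 4 (0.24 log units; that floor lies within the scatter), gives only a floor, so the true distance between those two compounds stays unread.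

The compounds shown leave open whether the thiophene ring or its amine drives the change. An unsubstituted thiophene or an aminophenyl group on the same carbonyl carbon would separate the two.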